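Fluoro in place of hydrogen on the phenyl ring

The compounds below may be only part of what the source reports. "The series", "measured", "known", "first", "only" and "open" are said of these compounds alone.

compound 1, `COc1cc(-c2noc(Cc3c[nH]c4ccccc34)n2)cc(OC)c1OC`, 2800 nM
compound 2, `c1ccc(-c2noc(Cc3c[nH]c4ccccc34)n2)cc1`, > 50000 nM

In a functional assay on cells (Splenocyte, Mus musculus, strain BALB/c) for inhibition, read by scintillation counting and thymidine incorporation, with stated times of 48 h and 8 h (a lower number here means a stronger inhibitor, a higher number a weaker inhibitor), compound 1 gives 2800 nM. For compound 2 the value > 50000 nM is a limit of this assay and not a number, as the limit of > 50000 nM in this assay, at which 1 of the 2 values shown sits, records. Compound 2 thus stands at the weak end of the two values shown. Compound 3, `Fc1ccc(-c2noc(Cc3c[nH]c4ccccc34)n2)cc1`, is not yet measured in this assay. It differs from compound 2 by fluoro in place of hydrogen on an aromatic carbon. Going by the values given here, with only a limit for compound 2, no measured step gives a direction. Compound 3 is expected to stay near that limit, so the step of a number no higher from compound 2 to compound 3 (the limit leaves the size open) is estimated as none beyond the scatter. Compound 3 is estimated at 50000 nM, between 15000 nM and 200000 nM.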

Compound 3, half-maximal inhibitory concentration: 13600 nM
For compound 3 the middle estimate is 3.7-fold (0.57 log units) above the measured one, and the stated range ends above it.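

Phenyl to 4-fluorophenyl, on an aromatic carbon para to a large group, brings an at least 3.6-fold lower number from compound 2 to compound 3 (0.56 log units; beyond the scatter) in this assay. Going by these compounds alone, this shows that this position responds to a single fluoro, which the earlier compounds could not show. The value of compound 2 is a limit and not a number: the limit of > 50000 nM in this assay, at which 1 of the 3 values shown sits.

The compounds shown leave open whether a chlorine atom, an amine or a carboxylic acid in place of the fluoro would give a step of the same direction. They also leave open what fluoro would do at any other carbon of this ring.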